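A Second Hydroxy Group on Compound 3

A few compounds are considered here, and "the series" means these few. Any claim that something is new, unique, unknown or untested is made for them only; others in the source may bear on it.

Of the compounds shown here, three with one shared core have been tested in a functional assay on MDA-MB-231 cells (Homo sapiens) for cytotoxicity, read by sulforhodamine B assay, with a stated time of 72 h; on this read-out higher numbers stand for an effect only at larger amounts of compound and lower numbers for an effect already at smaller amounts. Compound 1 `Cc1cccc(-c2cc3occ(C)c3c(=O)o2)c1` gives > 83.3 uM, which is a limit and not a number. Compound 2 `CCOc1cccc(-c2cc3occ(C)c3c(=O)o2)c1` gives > 37 uM, which is also a limit. Compound 3 `Cc1coc2cc(-c3cccc(O)c3)oc(=O)c12` gives > 41.3 uM, again a limit, so it has no number of its own to start from.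

The next compound, compound 4 `Cc1coc2cc(-c3ccc(O)c(O)c3)oc(=O)c12`, differs from compound 3 at one place, with hydroxy in place of hydrogen on an aromatic carbon. The new group sits ortho to the hydroxy group that compound 3 already carries and para to a large group.

The measured steps give little to go on. They comprise a step that the two limits leave unreadable from compound 1 to compound 2, a step that the two limits leave unreadable from compound 1 to compound 3 and a step that the two limits leave unreadable from compound 2 to compound 3. None has a readable size, so none of them sizes the new change, and no shift beyond the scatter in either direction can be argued from them. The expectation therefore stays close to the limit of compound 3, and another limit in this assay is quite possible. The step expected is a step that the limit leaves unreadable from compound 3 to compound 4. For compound 4 the estimated value is 45 uM, with an expected range of 15 uM to 90 uM.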

Compound 4, concentration for half-maximal effect: 22.9 uM
Compound 4: the middle estimate sits 2.0-fold (0.29 log units) above what was measured; measured number inside the range.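

In this assay compound 4 gives 22.9 uM, and it is the only one of the four compounds shown with a number rather than a limit, whereas every step among the earlier compounds cannot be read. This makes the place ortho to a hydroxy group and para to a large group the one change shown here that is tied to a readable value, with hydroxy in place of hydrogen on an aromatic carbon giving an at least 1.8-fold lower number from compound 3 to compound 4 (0.25 log units; that floor lies within the scatter). That floor does not establish a shift beyond the scatter, and the true step could be larger, because compound 3 carries only a limit: the limit of > 41.3 uM in this assay, at which 1 of the 4 values shown sits.

The compounds shown leave open whether the new hydroxy group would give the same value without the hydroxy group that compound 3 already carries, or whether the pair of hydroxy groups is what counts. They also leave open whether another group at the same place, such as a methoxy group, an amine or a fluorine atom, would match the hydroxy group, or whether a carboxylic acid there would move the value in either direction.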